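A few compounds are considered here, and "the series" means these few. Any claim that something is new, unique, unknown or untested is made for them only; others in the source may bear on it.

Measured so far: compound 1 `Cn1c(-c2ccc(NC(=O)CCl)cc2)nc(-c2ccccc2)c1-c1ccccc1`, in a functional assay on MCF7 cells (Homo sapiens) for cytotoxicity, read by MTT assay, with a stated time of 24 h (a lower number here means a stronger inhibitor, a higher number a weaker inhibitor), compound 1 gives 42.6 ug/mL; compound 2 `CCN1CCN(CC(=O)Nc2ccc(-c3nc(-c4ccccc4)c(-c4ccccc4)n3C)cc2)CC1`, in this assay compound 2 gives 80 ug/mL.

Compound 2 and compound 1 are not separated on these numbers: the step of a 1.9-fold higher number from compound 1 to compound 2 (0.27 log units; within the scatter) lies within the scatter. Compound 3 `Cn1c(-c2ccc(NC(=O)CN3CCN(Cc4ccc(Cl)cc4)CC3)cc2)nc(-c2ccccc2)c1-c1ccccc1` carries 4-chlorophenyl in place of methyl on a saturated chain carbon bound to an amine nitrogen in a ring. Going by the values given here, no measured step touches this place; the only step known, from the chloro to the piperazine on the carbon bound to the carbonyl, was within the scatter, so there is no basis for expecting a step beyond the scatter here. Compound 3 is therefore expected at 60 ug/mL, range 25 ug/mL to 150 ug/mL, the estimated step being a 1.3-fold lower number from compound 2 to compound 3 (0.12 log units; within the scatter).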

Compound 3, half-maximal inhibitory concentration: 21 ug/mL
Estimate against measurement, compound 3: 2.9-fold (0.46 log units) above; the whole stated range lies above it.
By their numbers in this assay, from the lowest: compound 3; then compounds 1 and 2 (each within the scatter of the next).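

In this assay, going by these compounds alone, the change from ethyl to 4-chlorobenzyl on the piperazine gives a 3.8-fold lower number from compound 2 to compound 3 (0.58 log units; beyond the scatter), the first step beyond the scatter. This position therefore responds to the entering 4-chlorophenyl, whereas the earlier replacement of chloro did not separate its pair, though the step is modest and rests on this single pair. No measured evidence on the compounds accounts for the step.

From the compounds shown here alone, whether the chlorine or the aromatic ring carries the step remains open. A plain benzyl or a longer chain ending in 4-chlorophenyl would address this.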